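The compounds below may be only part of what the source reports. "The series", "measured", "known", "first", "only" and "open" are said of these compounds alone.

Measured in an ADME assay on cells (Hepatocyte, Rattus norvegicus) for metabolic stability, using equilibrium dialysis; on this read-out higher numbers stand for fast clearance and lower numbers for slow clearance:
compound 1 `CC(=O)N[C@@H]1CCC[C@H](C(=O)Nc2cc(-c3cnn4c3CN(C)CC4)c(Cl)cn2)C1`, 7.7 uL/min;
compound 2 `CC(=O)N[C@@H]1CCC[C@H](C(=O)Nc2cc(-c3cnn4c3CC(C)(C)C4)c(Cl)cn2)C1`, 73 uL/min.

Among the compounds with values here, compound 2 stands highest of the two numbers, separated from compound 1 by the only measured step, a 9.5-fold higher number from compound 1 to compound 2 (0.98 log units; beyond the scatter). Compound 3 `CC(=O)N[C@@H]1CCC[C@H](C(=O)Nc2cc(-c3cnc4n3CC(C)(C)C4)c(Cl)cn2)C1` differs from compound 2 by a group of 10 heavy atoms (8 carbon, 2 nitrogen; one five-membered non-aromatic ring with 1 hetero atom, one five-membered aromatic ring with 2 hetero atoms) in place of a group of 10 heavy atoms (8 carbon, 2 nitrogen; one five-membered non-aromatic ring with 1 hetero atom, one five-membered aromatic ring with 2 hetero atoms), on an aromatic carbon The two groups share the same atoms, joined differently. Within the data shown here, no measured step covers a rearrangement of this kind; the step from compound 1 to compound 2 exchanged a different group and does not bear on it. With no guide, no step beyond the scatter is expected, and compound 3 is estimated at 60 uL/min (range 20 uL/min to 180 uL/min), that is a 1.2-fold lower number from compound 2 to compound 3 (0.09 log units; within the scatter).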

Compound 3, intrinsic clearance in a liver preparation (reported as CLH), per the amount of preparation that the assay uses: 28 uL/min
For compound 3 the middle estimate is 2.1-fold (0.33 log units) above the measured one; the measured number falls inside the stated range.
By their numbers in this assay, from the lowest: compound 1; then compound 3; then compound 2.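

In this assay, rejoining the same atoms on the aromatic carbon opposite the ring nitrogen is enough to give a 2.6-fold lower number from compound 2 to compound 3 (0.42 log units; beyond the scatter), so this position responds to how the group is connected, even with identical atom, donor and acceptor counts. The rearranged group still does not match the group with the six-membered non-aromatic ring, with a 3.6-fold higher number from compound 1 to compound 3 (0.56 log units; beyond the scatter). Nothing available gives a cause for either step. Still open, as far as these compounds go, is how the rearranged group would behave with a ring ether oxygen in place of its two methyl groups.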